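Shifting the Chlorine on Compound 3

This account rests on a few compounds, and the source may have more. Where it says the series, first, only, none or still open, it means among the compounds named here.

Of the compounds shown here, three sharing one core have been tested in a functional assay on KB cells (Homo sapiens) for inhibition, read by MTT assay, with a stated time of 24 h, tested at 1 ug/mL; a lower number here means less inhibition of growth, a higher number more inhibition of growth at the concentration tested. Compound 1 `CC(=O)SCCC(CCCCC(=O)O)SC(C)=O` gives 12.4%. Compound 2 `CC(=O)SCCC(CCCCC(=O)Nc1ccccc1)SC(C)=O` gives 1.68%, and compound 3 `CC(=O)SCCC(CCCCC(=O)Nc1cccc(Cl)c1)SC(C)=O` gives 0.04%. Compound 3 thus lies within the scatter of compound 2 and clearly under compound 1, as the step of a number 12.4 percentage points lower from compound 1 to compound 3 (beyond the scatter) shows; the step of a number 1.6 percentage points lower from compound 2 to compound 3 (within the scatter) is the only one touching the chlorine. Compound 4 `CC(=O)SCCC(CCCCC(=O)Nc1ccc(Cl)cc1)SC(C)=O` differs from compound 3 in one place: 4-chlorophenyl in place of 3-chlorophenyl on an amide-type nitrogen. For the measured compounds named here, no measured step moves a chlorine from one ring carbon to another, so the expectation rests on the small step of a number 1.6 percentage points lower from compound 2 to compound 3 (within the scatter), and the expected step is a number 2 percentage points higher from compound 3 to compound 4 (within the scatter), nothing beyond the scatter. Compound 4 is estimated at 2%, between 0% and 10%.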

Compound 4, percent growth inhibition at one concentration: 14.8%
Estimate against measurement, compound 4: 12.8 percentage points below, outside the stated range (above it).
By their numbers in this assay, from the lowest: compounds 3 and 2 (each within the scatter of the next); then compounds 1 and 4 (each within the scatter of the next).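

With the same atoms joined differently, 4-chlorophenyl in place of 3-chlorophenyl on the amide-type nitrogen gives a number 14.8 percentage points higher from compound 3 to compound 4 (beyond the scatter), so the place of the chlorine on the ring counts here. Chloro in place of hydrogen now also gives a step beyond the scatter, a number 13.1 percentage points higher from compound 2 to compound 4 (beyond the scatter), unlike the step to compound 3. Replacing hydroxy on the carbonyl carbon with (4-chlorophenyl)amino gives a number 2.4 percentage points higher from compound 1 to compound 4 (within the scatter), so that pair cannot be told apart. Nothing measured here explains the effect of moving the chlorine. Going by these compounds, whether bromo or methoxy in place of the chlorine in 4-chlorophenyl would read the same remains open.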